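Meta substituent swap on the aryl ring of compound 3

The compounds below may be only part of what the source reports. "The series", "measured", "known", "first", "only" and "open" are said of these compounds alone.

Compound 1 `Cc1ccc2ccc(-c3cccc(OC(F)(F)F)c3)cc2n1` gives > 10000 nM in a functional assay on CHO cells for inhibition of metabotropic glutamate receptor 5 (Rattus norvegicus), read by FLIPR and calcium flux (a higher number here means a weaker inhibitor, a lower number a stronger inhibitor), a limit of the assay rather than a number. Compound 2 `Cc1ccc2ccc(-c3cc(Cl)cc(C#N)c3)cc2n1` gives 1.4 nM and compound 3 `COCc1cc(C#N)cc(-c2ccc3ccc(C)nc3c2)c1` gives 2 nM in this assay; the step of a 1.4-fold higher number from compound 2 to compound 3 (0.15 log units; within the scatter) is small. Compound 3 thus holds the higher of the two numbers, with compound 2 nearest and within the scatter. Compound 4 `Cc1ccc2ccc(-c3cc(C#N)cc(OC(F)(F)F)c3)cc2n1` differs from compound 3 by trifluoromethoxy in place of methoxymethyl on an aromatic carbon. Going by the values given here, the only measured step bearing on this is a 1.4-fold higher number from compound 2 to compound 3 (0.15 log units; within the scatter), a swap at the same place that stayed within the scatter. Compound 1 also carries trifluoromethoxy but lacks the cyano group and sits at the limit of > 10000 nM in this assay, at which 1 of the 3 values shown sits. The expected step is a 2.5-fold higher number from compound 3 to compound 4 (0.40 log units; beyond the scatter), modest. Compound 4 is estimated at 5 nM, between 1 nM and 40 nM.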

Compound 4, half-maximal inhibitory concentration: 75 nM
Compound 4: the middle estimate sits 15-fold (1.18 log units) below what was measured; the whole stated range lies below it.
By their numbers in this assay, from the lowest: compounds 2 and 3 (each within the scatter of the next); then compound 4. At a limit, above all of these: compound 1.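

At this position, the swap from chloro to methoxymethyl stayed within the scatter, but trifluoromethoxy does not hold that level in this assay, with a 38-fold higher number from compound 3 to compound 4 (1.57 log units; beyond the scatter) and a 54-fold higher number from compound 2 to compound 4 (1.73 log units; beyond the scatter). The position therefore distinguishes among these three groups, even with the cyano group unchanged. With trifluoromethoxy held fixed, cyano in place of hydrogen gives an at least 130-fold lower number from compound 1 to compound 4 (2.12 log units; beyond the scatter), a step read against a limit of compound 1 rather than a number: the limit of > 10000 nM in this assay, at which 1 of the 4 values shown sits.

On these data alone, how an amine or a longer ether chain would stand at this position remains open. The compounds shown also do not separate the effect of the fluorine atoms from the larger heavy-atom count of trifluoromethoxy.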